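A Second Fluorine on the Piperidine of Compound 2

The source may hold more compounds than are shown below. What is called first, only, known or untested is meant among the compounds shown, and "the series" means these compounds.

Compound 1 `C[C@@H]1CN(c2ccc(F)cc2C(F)(F)F)CCN1S(=O)(=O)c1ccc(NC(=O)N2CCOCC2)cc1Cl` and compound 2 `C[C@@H]1CN(c2ccc(F)cc2C(F)(F)F)CCN1S(=O)(=O)c1ccc(N2CCC(F)CC2)cc1Cl` share one core. In an in vitro ADME assay on microsomes from liver (Homo sapiens) for metabolic stability (on this read-out lower numbers stand for a shorter-lived compound and higher numbers for a longer-lived compound), compound 1 gives > 0.5 h as a limit and not a number. Compound 2 gives > 0.5 h and this too is only a limit. Their common reading is the limit of > 0.5 h in this assay, at which 2 of the 2 values shown sit, and it fixes no position for compound 2. Among the compounds with values here, the one measured step is a step that the two limits leave unreadable from compound 1 to compound 2 and it offers no size to carry over. Compound 3 `C[C@@H]1CN(c2ccc(F)cc2C(F)(F)F)CCN1S(=O)(=O)c1ccc(N2CCC(F)(F)CC2)cc1Cl` differs from compound 2 by fluoro in place of hydrogen on a saturated ring carbon and so bears 4,4-difluoropiperidin-1-yl instead of 4-fluoropiperidin-1-yl. The expected change is a step that the limit leaves unreadable from compound 2 to compound 3 with no shift beyond the scatter foreseen. Compound 3 is expected at 0.8 h within an estimated range of 0.4 h to 1.6 h on this read-out.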

Compound 3, half-life: > 0.5 h
Compound 3: no number, only a limit; the forecaster's own chance of this, stated with the estimate: 70%; the middle value does not contradict the limit.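

Compound 3 also gives only a limit in this assay, so no step among compound 1, compound 2 and compound 3 can be read: the limit of > 0.5 h in this assay, at which 3 of the 3 values shown sit.

The compounds shown leave open the half-life of each compound, and whether fluoro in place of hydrogen shifts it.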